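A few compounds are considered here, and "the series" means these few. Any claim that something is new, unique, unknown or untested is made for them only; others in the source may bear on it.

Compound 1 `Cc1cc([Si](C)(C)C)c2cn[nH]c2c1` gives 50% in an assay for inhibition of Indoleamine 2,3-dioxygenase 1 (Homo sapiens), read by spectrophotometry, with a stated time of 30 min, tested at 10 uM; a higher number here means more inhibition at the concentration tested (going by the name of the read-out), a lower number less inhibition.
Compound 2 `C[Si](C)(C)c1cccc2[nH]ncc12` gives 7.2%.
Compound 3 `OC(Cc1ccccc1)c1cccc2[nH]ncc12` gives 13%.

Compound 3 stands second highest of these three numbers: its gap to compound 2 is within the scatter, while compound 1 lies beyond the scatter above it. Compound 4 `Cc1cc(C(O)Cc2ccccc2)c2cn[nH]c2c1` differs from compound 3 by a single change: methyl in place of hydrogen on an aromatic carbon. For the measured compounds named here, one measured step bears on this change, running the opposite way: a number 42.8 percentage points lower from compound 1 to compound 2 (beyond the scatter). Reversing that step, a methyl entering compound 3 is expected to raise the number by a large amount, although only this one pair supports such a reading. The step from compound 3 to compound 4 is estimated at a number 29 percentage points higher from compound 3 to compound 4 (beyond the scatter). Compound 4 is therefore expected to give 42%, with a range from 15% to 68%.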

Compound 4, a percentage reported as inhibition, at one concentration (the size of the read-out at that concentration, not a potency): 76%
Compound 4: the middle estimate sits 34 percentage points below what was measured; the whole stated range lies below it.
By their numbers in this assay, from the lowest: compounds 2 and 3 (each within the scatter of the next); then compound 1; then compound 4.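

Methyl in place of hydrogen on this aromatic carbon, para to a fused ring, gives a number 63 percentage points higher from compound 3 to compound 4 (beyond the scatter) in this assay. The rise is therefore no longer tied to a single pair of compounds: it now appears on a second core, with the same direction. The size of the rise, however, differs with the core: the same change on two cores in this assay, a number 42.8 percentage points lower (beyond the scatter) from compound 1 to compound 2 and a number 63 percentage points lower (beyond the scatter) from compound 4 to compound 3, 20.2 percentage points apart, beyond the scatter of two such steps

The compounds shown leave open whether ethyl, chlorine or an amine at this position would raise the number as methyl does. Going by these compounds, whether methyl would do so on any further core also remains open.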